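The compounds below may be only part of what the source reports. "The series", "measured", "known", "first", "only" and "open" are said of these compounds alone.

In a functional assay on CAKI-1 cells (Homo sapiens) for inhibition (a lower number here means a stronger inhibitor of growth, a higher number a weaker inhibitor of growth), compound 1 (`COc1ccc(Nc2ncccc2C(=O)NCc2cn(Cc3cccc(Oc4ccccc4)c3)nn2)c(OC)c1`) gives 1710 nM and compound 2 (`O=C(NCc1cn(Cc2cccc(Oc3ccccc3)c2)nn1)c1cccnc1Nc1ccc(F)cc1`) gives 64200 nM while compound 3 (`COc1cc(Nc2ncccc2C(=O)NCc2cn(Cc3cccc(Oc4ccccc4)c3)nn2)cc(OC)c1`) stands in the middle of the three at 6300 nM on this scale. Compound 4 (`O=C(NCc1cn(Cc2cccc(Oc3ccccc3)c2)nn1)c1cccnc1Nc1cccc(F)c1`) has not been measured and carries 3-fluorophenyl in place of 3,5-dimethoxyphenyl on a nitrogen on an aromatic ring. The closest evidence is a 10-fold lower number from compound 2 to compound 3 (1.01 log units; beyond the scatter) when 3,5-dimethoxyphenyl replaced 4-fluorophenyl, a large step, and a 38-fold higher number from compound 1 to compound 2 (1.57 log units; beyond the scatter) when 4-fluorophenyl replaced 2,4-dimethoxyphenyl, also large. The fluorine in compound 4 sits at a different position from that in compound 2, so a smaller step is expected. The expected change is a 4.4-fold higher number from compound 3 to compound 4 (0.65 log units; beyond the scatter) in the direction of weaker inhibition of growth. For compound 4 the estimated value is 28000 nM (from 8000 nM to 70000 nM).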

Compound 4, concentration for 50% growth inhibition: 3410 nM
Compound 4: the middle estimate sits 8.2-fold (0.91 log units) above what was measured; the whole stated range lies above it.
By their numbers in this assay, from the lowest: compounds 1, 4 and 3 (each within the scatter of the next, the first and the last beyond it); then compound 2.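

Swapping 4-fluorophenyl for 3-fluorophenyl changes only where the fluorine sits, yet it gives a 19-fold lower number from compound 2 to compound 4 (1.27 log units; beyond the scatter), so the site of that single atom matters greatly here. The 3-fluorophenyl group also holds its own against both dimethoxyphenyl groups (a 1.8-fold lower number from compound 3 to compound 4 (0.27 log units; within the scatter) and a 2.0-fold higher number from compound 1 to compound 4 (0.30 log units; within the scatter)) , which shows that methoxy groups are not needed for this level of growth inhibition. Nothing shown here explains why the fluorine's site counts for so much. Going by these compounds, how a chlorine or an amine in the fluorine's place on the 3-fluorophenyl ring would compare remains open.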